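The compounds below may be only part of what the source reports. "The series", "measured", "known", "first", "only" and "open" are said of these compounds alone.

Measured so far in an ADME assay on microsomes from liver (Homo sapiens) for metabolic stability, with a stated time of 10 min; on this read-out lower numbers stand for a less stable compound and higher numbers for a more stable compound:
- compound 1 `COc1ccc2oc(-c3cn4nc(OC)sc4n3)cc2c1`: 30%
- compound 2 `c1ccc(Sc2nn3cc(-c4cc5ccccc5o4)nc3s2)cc1`: "not determined" (no result reported)

The account follows the step away from compound 2, and that starting point is weak. In this assay, compound 2 stands at "not determined" (no result reported), so it offers no single number to measure from. The next structure, compound 3 `CCSc1nn2cc(-c3cc4ccccc4o3)nc2s1`, has not yet been measured. The structural change is ethyl in place of phenyl on a sulfur. In words, ethyl takes the place of phenyl on a sulfur.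

No measured step between any of these compounds is available, so the size of this change in this assay can only be expected, not read. Among the measured compounds shown here, the one number at hand is that of compound 1, at 30%. No step beyond the scatter from that level is expected, and no direction can be favoured. The expected value for compound 3 is 30%, within an estimated range of 10% to 55%.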

Compound 3, percent of the compound remaining: 45%
The estimate for compound 3 lay 15 percentage points below the measured number, within the range that was stated.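

In this assay, among the compounds shown here, compound 2 stands at "not determined" (no result reported) and compound 3 at 45% so no step between the two can be read. The compounds shown leave open how phenylsulfanyl and ethylsulfanyl compare on this read-out, and no supporting evidence bears on the result.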